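This account rests on a few compounds, and the source may have more. Where it says the series, first, only, none or still open, it means among the compounds named here.

In a physicochemical assay for lipophilicity (a higher number here means a more lipophilic compound, a lower number a more polar compound), compound 1 `Clc1cccc(Cl)c1C1=NC(c2ccccc2)CO1` gives 3.69 and compound 2 `CCOc1ccccc1C1=NC(c2ccccc2)CO1` gives 4.22 while compound 3 `Cc1cccc(C2=NC(c3ccccc3)CO2)c1` gives 4.11 on the same scale. That puts compound 3 level with compound 2 within the scatter, and beyond the scatter above compound 1. Compound 4 `COc1cccc(C2=NC(c3ccccc3)CO2)c1` differs from compound 3 in one place: methoxy in place of methyl on an aromatic carbon, meta to a large group. Within the data shown here, no pair of measured compounds shows this swap, so the expectation rests on the structural change alone: a modest fall in this assay that may only just clear the scatter. The expected step is a number 0.36 log units lower from compound 3 to compound 4 (beyond the scatter) by this estimate. Compound 4 is estimated at 3.75 within a range from 3.35 to 4.1 once measured.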

Compound 4, partition coefficient: 3.77
Beside the measured number, compound 4's estimate is 0.02 log units below it; measured number inside the range.
By their numbers in this assay, from the lowest: compounds 1 and 4 (each within the scatter of the next); then compounds 3 and 2 (each within the scatter of the next).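

In this assay, among these compounds, methoxy in place of methyl on an aromatic carbon, meta to a large group, gives a number 0.34 log units lower from compound 3 to compound 4 (beyond the scatter), the first step here between compounds that differ in one place. The swap adds one heavy atom and one hydrogen-bond acceptor, and the modest step lies beyond the scatter. Nothing measured here accounts for the step. Going by these compounds, how an amine or a carboxylic acid at this position would fall on this scale stays open. So does whether the same swap elsewhere on the ring would give a similar step.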